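Removing an Ethyl Group from a Coumarin Ester

The source may hold more compounds than are shown below. What is called first, only, known or untested is meant among the compounds shown, and "the series" means these compounds.

Of the compounds shown here, three have been measured in an assay on isolated protein (strain Sprague-Dawley) for inhibition of Amine oxidase [flavin-containing] A (Rattus norvegicus), read by spectrophotometry, with a stated time of 5 min, tested at 10 uM; on this read-out higher numbers stand for more inhibition at the one concentration tested (going by the name of the read-out) and lower numbers for less inhibition. Compound 2 `CCOc1cc(=O)oc2cc(OCc3cccc(F)c3)ccc12` gives 25%. Compound 1 `O=c1cc(O)c2ccc(OCc3cccc(F)c3)cc2o1` gives 0%, and the change between them, (hydrogen in place of ethyl on an oxygen on an aromatic ring), produced a number 25 percentage points lower from compound 2 to compound 1 (beyond the scatter). Compound 3 `CCOC(=O)c1cc(=O)oc2cc(OCc3cccc(Cl)c3)ccc12` gives 4.4% in this assay; the difference between its core and that of compound 2 is not broken down here.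

Compound 4 `O=C(O)c1cc(=O)oc2cc(OCc3cccc(Cl)c3)ccc12` has not yet been measured. It differs from compound 3 by hydrogen in place of ethyl on an oxygen next to a carbonyl group. This is the same kind of change as that from compound 2 to compound 1, but not the same: there the oxygen sits on an aromatic ring with an aromatic carbon as its other neighbour, here it sits next to a carbonyl group whose other neighbour is the carbonyl carbon. The earlier step was a modest drop, and compound 3 already stands low in this assay with 4.4%, so little room for a drop remains. For compound 4 a step of a number 2.4 percentage points lower from compound 3 to compound 4 (within the scatter) is expected. Compound 4 is therefore estimated at 2%, between 0% and 12%.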

Compound 4, a percentage reported as inhibition, at one concentration (the size of the read-out at that concentration, not a potency): 0%
Beside the measured number, compound 4's estimate is 2 percentage points above it; measured number inside the range.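

In this assay the new step is a number 4.4 percentage points lower from compound 3 to compound 4 (within the scatter), and set beside the earlier step it shows that hydrogen in place of ethyl does not have one size across these two cores: the same change on two cores in this assay, a number 25 percentage points lower (beyond the scatter) from compound 2 to compound 1 and a number 4.4 percentage points lower (within the scatter) from compound 3 to compound 4, 20.6 percentage points apart, beyond the scatter of two such steps The new step lies within the scatter, so it neither confirms nor rules out a drop on this core, where compound 3 gives only 4.4%. Nor do these two pairs show what sets the steps apart: one reads ethoxy to hydroxy and the other ethoxycarbonyl to carboxy, and the first pair carries fluorine where the second carries chlorine.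

The compounds shown leave open how an amide, a methyl ester or a longer chain would read in place of the ethoxycarbonyl group of compound 3. They also leave open whether the same step would read differently if compound 3 and compound 4 carried fluorine in place of chlorine.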